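Branched Alkylamino for Pyrrolidinyl on a Shared Core

The compounds below may be only part of what the source reports. "The series", "measured", "known", "first", "only" and "open" are said of these compounds alone.

Measured compounds:
- compound 1 `CCCCN(CC)c1nc(C)nc2c1nnn2-c1c(C)cc(C)nc1C` in an in vitro assay on 293-EBNA cells for binding affinity to corticotropin-releasing factor receptor 1 (Homo sapiens) (a higher number here means a weaker inhibitor, a lower number a stronger inhibitor), gives 65 nM
- compound 2 `Cc1nc(N2CCCC2)c2nnn(-c3ccc(C(C)C)cc3Br)c2n1` in this assay gives 194 nM
- compound 3 `CCCCN(CC)c1nc(C)nc2c1nnn2-c1c(Br)cc(OC)cc1OC` in this assay gives 3 nM

Compound 2 stands at the highest of the three numbers; compound 1 and compound 3 both give lower numbers, and both gaps lie beyond the usual scatter. Compound 4 `CCCCC(CC)Nc1nc(C)nc2c1nnn2-c1ccc(C(C)C)cc1Br` has not been measured. It differs from compound 2 in one place: (1-ethylpentyl)amino in place of pyrrolidin-1-yl on an aromatic carbon. The two compounds with lower numbers, compound 1 and compound 3, carry an open-chain amino group on the same position of the shared core. On that basis a step toward a lower number in this assay, clearly beyond the scatter, is expected for compound 4, with a 4.9-fold lower number from compound 2 to compound 4 (0.69 log units; beyond the scatter). Compound 4 is estimated at 40 nM, within a range of 10 nM to 150 nM.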

Compound 4, inhibition constant: 3.1 nM
Compound 4: middle estimate off by 13-fold (1.11 log units), on the high side; measured number outside the range, below it.
By their numbers in this assay, from the lowest: compounds 3 and 4 (each within the scatter of the next); then compound 1; then compound 2.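

In this assay, with everything else held fixed, swapping pyrrolidin-1-yl for (1-ethylpentyl)amino gives a 63-fold lower number from compound 2 to compound 4 (1.80 log units; beyond the scatter), a large step. For the compounds shown here, the earlier compounds differ in more than one place, so this pair is the first to show that the group on this aromatic carbon, next to the ring nitrogen, strongly affects the number on its own. No measurement here accounts for the step.

The change removes a ring, enlarges the group and adds a hydrogen-bond donor at once, so these cannot be separated. From the compounds shown here alone, whether diethylamino or piperidin-1-yl at this position would give a similar number remains open.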